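From compound 3 to compound 4: amide group change

This account rests on a few compounds, and the source may have more. Where it says the series, first, only, none or still open, it means among the compounds named here.

Values in a functional assay on KB cells (Homo sapiens) for antiproliferative activity, read by sulforhodamine B assay, with a stated time of 3 days; on this read-out higher numbers stand for weaker inhibition of growth and lower numbers for stronger inhibition of growth:
- compound 1 `O=C(Nc1nccs1)c1cccc(Nc2ncc(F)c(Nc3ccc(F)cc3)n2)c1`: > 10000 nM (a limit)
- compound 2 `O=C(Nc1ccc(C(F)(F)F)cc1)c1cccc(Nc2ncc(F)c(Nc3ccc(F)cc3)n2)c1`: > 10000 nM (a limit)
- compound 3 `O=C(c1cccc(Nc2ncc(F)c(Nc3ccc(F)cc3)n2)c1)N1CCCCC1`: 14800 nM

Among the measured compounds shown here, compound 3 gives 14800 nM, the only actual number so far. The other two compounds stand at the limit of > 10000 nM in this assay, at which 2 of the 3 values shown sit.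

Compound 4 `COc1cc(NC(=O)c2cccc(Nc3ncc(F)c(Nc4ccc(F)cc4)n3)c2)cc(OC)c1` carries (3,5-dimethoxyphenyl)amino in place of piperidin-1-yl on a carbonyl carbon.

For the measured compounds named here, two measured steps bear on this change, and both run in the opposite sense, towards piperidin-1-yl. Going by the values given here, the first is a step that the limit leaves unreadable from compound 1 to compound 3. The second is a step that the limit leaves unreadable from compound 2 to compound 3. Neither size can be read, so the data give no measured size or direction for this change. No step beyond the scatter is therefore expected in this assay, and a result reported only as a limit is quite possible. The estimated step is a 1.1-fold lower number from compound 3 to compound 4 (0.02 log units; within the scatter). The estimate for compound 4 is 14000 nM, with an expected range of 4000 nM to 40000 nM.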

Compound 4, concentration for 50% growth inhibition: 15500 nM
The estimate for compound 4 lay 1.1-fold (0.04 log units) below the measured number; low and high end bracket the measured number.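

Within this assay the exchange of piperidin-1-yl for (3,5-dimethoxyphenyl)amino on a carbonyl carbon is a 1.0-fold higher number from compound 3 to compound 4 (0.02 log units; within the scatter) and is the first readable step at this position. A ring amide without the amide hydrogen and an aryl amide that carries it therefore stand within the scatter of each other, despite the larger entering group with its hydrogen-bond donor and acceptors. The steps from compound 1 and from compound 2 to compound 4 cannot be read, as the values of those two compounds are limits: the limit of > 10000 nM in this assay, at which 2 of the 4 values shown sit.

As far as these compounds go, it remains open whether a morpholin-4-yl group or a phenylamino group bearing a carboxylic acid on this carbonyl carbon would move the number beyond the scatter. All the compounds shown keep the rest of the core constant, so what other parts of it contribute also stays open.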